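A few compounds are considered here, and "the series" means these few. Any claim that something is new, unique, unknown or untested is made for them only; others in the source may bear on it.

Of the compounds shown here, three built on one shared core have been measured. Compound 1 `Cc1cc(C(=O)NCc2ccccc2)nn1Cc1cc(Cl)ccc1OCc1ccccc1` gives 39.8 nM in an assay on CHO-K1 cells for displacement of a labelled ligand from prostaglandin E2 receptor EP1 subtype (Homo sapiens); on this read-out lower numbers stand for stronger inhibition and higher numbers for weaker inhibition. Compound 2 `Cc1cc(NC(=O)CC2CCCCC2)nn1Cc1cc(Cl)ccc1OCc1ccccc1` gives 6.31 nM in this assay, and compound 3 `Cc1cc(NC(=O)C2CCOC2)nn1Cc1cc(Cl)ccc1OCc1ccccc1` gives 39.8 nM. Compound 3 stands level with compound 1, the two together carrying the highest numbers of the three, since no change at the digits printed from compound 1 to compound 3 (within the scatter). Compound 2 is the furthest from compound 3, as a 6.3-fold higher number from compound 2 to compound 3 (0.80 log units; beyond the scatter).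

Compound 4 `Cc1cc(NC(=O)C2CCOCC2)nn1Cc1cc(Cl)ccc1OCc1ccccc1` has not yet been measured. It differs from compound 3 in one place: oxan-4-yl in place of oxolan-3-yl on a carbonyl carbon. Among the compounds with values here, only one measured step touches the same carbonyl carbon, and that was a 6.3-fold higher number from compound 2 to compound 3 (0.80 log units; beyond the scatter), where a six-membered saturated ring on a methylene bridge stood against the oxolan-3-yl ring. Compound 4 keeps a ring oxygen but grows the ring by one carbon, so a modest gain, near the edge of the scatter, is the most that seems reasonable to expect. Compound 4 is therefore expected to give about 25 nM, within a range of 10 nM to 63 nM. The step from compound 3 to compound 4 is estimated as a 1.6-fold lower number from compound 3 to compound 4 (0.20 log units; within the scatter).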

Compound 4, half-maximal inhibitory concentration in the prostaglandin E2 receptor EP1 subtype assay: 63.1 nM
The estimate for compound 4 lay 2.5-fold (0.40 log units) below the measured number, and the stated range ends below it.
By their numbers in the prostaglandin E2 receptor EP1 subtype assay, from the lowest: compound 2; then compounds 1, 3 and 4 (each within the scatter of the next).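

In the prostaglandin E2 receptor EP1 subtype assay, oxan-4-yl and oxolan-3-yl on this carbonyl carbon cannot be told apart, with a 1.6-fold higher number from compound 3 to compound 4 (0.20 log units; within the scatter), so adding one carbon to the oxygen-bearing ring gives no readable difference here. Also in the prostaglandin E2 receptor EP1 subtype assay, compound 4 sits within the scatter of the benzylcarbamoyl compound, with a 1.6-fold higher number from compound 1 to compound 4 (0.20 log units; within the scatter), while the gap to cyclohexylmethyl, now seen with a second oxygen-bearing ring, is a 10-fold higher number from compound 2 to compound 4 (1.00 log units; beyond the scatter). In a physicochemical assay for lipophilicity, at pH 7.4 (a higher number here means a more lipophilic compound, a lower number a more polar compound), compound 3 gives > 3.7, which is a limit of the assay. In the physicochemical assay compound 4 gives > 3.7, which is also a limit of the assay. In the physicochemical assay the step between compound 3 and compound 4 cannot be read, each value being a limit of the assay: the limit of > 3.7 in the physicochemical assay, at which 2 of the 2 values shown sit.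

Compound 3 and compound 4 differ from compound 2 in the ring oxygen and the methylene bridge together, so the compounds shown do not separate these two features. Going by these compounds, an oxan-4-ylmethyl or a plain cyclohexyl group on the carbonyl carbon would address this, and an amine or a longer chain at this position remains open too.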